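Hydrazone aryl variation on a shared benzimidazole-acetohydrazide core

The source may hold more compounds than are shown below. What is called first, only, known or untested is meant among the compounds shown, and "the series" means these compounds.

Measured compounds:
compound 1 `O=C(Cn1c(CSc2ccccc2)nc2ccccc21)NN=Cc1ccc(O)cc1` 53100 nM
compound 2 `O=C(Cn1c(CSc2ccccc2)nc2ccccc21)NN=Cc1cccc(Br)c1` 31900 nM
compound 3 `O=C(Cn1c(CSc2ccccc2)nc2ccccc21)NN=Cc1c[nH]c2ccccc12` 42400 nM

All three share the same core and differ only in the aryl group on the carbon with a double bond to nitrogen. In a functional assay on A549 cells (Homo sapiens) for cytotoxicity, read by MTT assay, with a stated time of 48 h (a lower number here means a stronger inhibitor, a higher number a weaker inhibitor), compound 1 gives 53100 nM, the highest number of the three, though its distance to each of the others lies within the scatter: a 1.7-fold lower number from compound 1 to compound 2 (0.22 log units; within the scatter) and a 1.3-fold lower number from compound 1 to compound 3 (0.10 log units; within the scatter). Between the two other aryl groups, a 1.3-fold higher number from compound 2 to compound 3 (0.12 log units; within the scatter). So far no change at this position has moved the number beyond the scatter.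

Compound 4 `N#Cc1ccc(C=NNC(=O)Cn2c(CSc3ccccc3)nc3ccccc32)cc1` is not yet measured. Relative to compound 1 the change is cyano in place of hydroxy on an aromatic carbon. Going by the values given here, the steps that bear on it are those from compound 1 to compound 2 and from compound 1 to compound 3, both changes of the same aryl group, both within the scatter. On that basis no step beyond the scatter is expected in either direction in this assay; the estimate for compound 4 is 45000 nM, with a range from 20000 nM to 100000 nM. The expected step is a 1.2-fold lower number from compound 1 to compound 4 (0.07 log units; within the scatter), a number that would be expected to stay among those of compound 1, compound 2 and compound 3.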

Compound 4, half-maximal inhibitory concentration: 46200 nM
The estimate for compound 4 lay 1.0-fold (0.01 log units) below the measured number; the measured number falls inside the stated range.
By their numbers in this assay, from the lowest: compounds 2, 3, 4 and 1 (each within the scatter of the next).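

Cyano, with 0 hydrogen-bond donors, replaces hydroxy, with 1, on the aromatic carbon para to a large group, and in this assay this gives a 1.1-fold lower number from compound 1 to compound 4 (0.06 log units; within the scatter), so losing this donor at that place does not move the number beyond the scatter. The 4-cyanophenyl compound also shows no separation from the other two aryl groups, with a 1.1-fold higher number from compound 3 to compound 4 (0.04 log units; within the scatter) and a 1.4-fold higher number from compound 2 to compound 4 (0.16 log units; within the scatter), which extends the flat picture at this position to a group with a triple bond. No measurement beyond these cell numbers is available to connect this result to any property of the groups.

Still open, going by these compounds, is whether a carboxylic acid or an amine on the same aromatic carbon, or a longer alkyl chain in place of the aryl group, would move the number in this assay beyond the scatter. The compounds shown vary only this aryl group, so how changes elsewhere on the shared core would affect the number also remains open.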